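Methoxy in place of chloro on a scaffold without measured potency

A few compounds are considered here, and "the series" means these few. Any claim that something is new, unique, unknown or untested is made for them only; others in the source may bear on it.

Compound 1 `Cc1c(O)ccc2c1[C@H](Cn1cc(-c3ccc(Cl)cc3)nn1)[C@@]13CC(=O)[C@@](C)(CC[C@@H]21)C3` shows in a functional assay on SW480 cells (Homo sapiens) for cytotoxicity, read by MTT assay, with a stated time of 4 days (on this read-out higher numbers stand for weaker inhibition and lower numbers for stronger inhibition), only a limit, > 20000 nM.
Compound 2 `Cc1ccc(S(=O)(=O)Oc2ccc3c(c2C)[C@H](Cn2cc(-c4ccc(Cl)cc4)nn2)[C@@]24CC(=O)[C@@](C)(CC[C@@H]32)C4)cc1` shows in this assay likewise only a limit, > 20000 nM.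

Compound 1 thus has no measured number in this assay, only the limit. Among the compounds with values here, the single measured change, a step that the two limits leave unreadable from compound 1 to compound 2, is unreadable because of the limit of > 20000 nM in this assay, at which 2 of the 2 values shown sit. Compound 3 `COc1ccc(-c2cn(C[C@H]3c4c(ccc(O)c4C)[C@@H]4CC[C@@]5(C)C[C@]43CC5=O)nn2)cc1` differs from compound 1 by methoxy in place of chloro on an aromatic carbon. Within the data shown here, no measured step bears on this change, and compound 1 offers only a limit, so no direction can be read. Compound 3 is expected to stay at the limit, with an expected step that the limit leaves unreadable from compound 1 to compound 3. Compound 3 is estimated at 30000 nM, between 8000 nM and 100000 nM.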

Compound 3, half-maximal inhibitory concentration: > 20000 nM
Compound 3 was reported as a limit; the forecaster's own chance of this, stated with the estimate: 85%; the middle value does not contradict the limit.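

Compound 1 and compound 3 each give only a limit, so no step between them can be read, and the reason is the same for all three compounds: the limit of > 20000 nM in this assay, at which 3 of the 3 values shown sit.

The compounds shown leave open how far any change on the shared core moves potency in this assay.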